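Aryloxyacetamide series: carbamoyl to hydroxy at the anilide

The compounds below may be only part of what the source reports. "The series", "measured", "known", "first", "only" and "open" are said of these compounds alone.

Measured so far, in a functional assay on CLL cells (Homo sapiens) for cytotoxicity, read by MTT assay, with a stated time of 48 h; a lower number here means that less compound is needed, a higher number that more compound is needed for the effect:
compound 1 `C=C(CC)C(=O)c1ccc(OCC(=O)Nc2ccc(C(N)=O)cc2)c(Cl)c1Cl`, 3700 nM
compound 2 `C=C(CC)C(=O)c1ccc(OCC(=O)NC2CCN(CC(=O)OC)CC2)c(Cl)c1Cl`, 10600 nM
compound 3 `C=C(CC)C(=O)c1ccc(OCC(=O)Nc2ccc3nc[nH]c3c2)c(Cl)c1Cl`, 3200 nM

Compound 1 stands at the second highest of the three numbers. Compound 3 sits within the scatter of it: a 1.2-fold lower number from compound 1 to compound 3 (0.06 log units; within the scatter). Compound 2 gives the higher number of the set, beyond the scatter from compound 1; the two differ in more than one place, so the pair shows only that.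

Compound 4 `C=C(CC)C(=O)c1ccc(OCC(=O)Nc2ccc(O)cc2)c(Cl)c1Cl` is not yet measured. It differs from compound 1 as follows: hydroxy in place of carbamoyl on an aromatic carbon.

Among the measured compounds shown here, no measured step exchanges carbamoyl for hydroxy. For the measured compounds named here, the only step that touches the same amide-type nitrogen is the one from compound 1 to compound 3, which swaps the whole aryl group and stays within the scatter. On that basis no step beyond the scatter is expected in this assay for compound 4; the estimated step is no change at the digits printed from compound 1 to compound 4 (within the scatter). Compound 4 is thus expected to give about 3700 nM, in the range 1500 nM to 9000 nM.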

Compound 4, half-maximal effective concentration: 6400 nM
For compound 4 the middle estimate is 1.7-fold (0.24 log units) below the measured one, within the range that was stated.
By their numbers in this assay, from the lowest: compounds 3, 1, 4 and 2 (each within the scatter of the next, the first and the last beyond it).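

In this assay, hydroxy in place of carbamoyl on the aromatic carbon, with one heavy atom entering where three leave, gives a 1.7-fold higher number from compound 1 to compound 4 (0.24 log units; within the scatter), so this exchange produces no step beyond the scatter. The change of the whole aryl group reads the same way: 4-hydroxyphenyl in place of 1H-benzimidazol-6-yl gives a 2.0-fold higher number from compound 3 to compound 4 (0.30 log units; within the scatter), which leaves the aromatic groups on the amide nitrogen of compounds 1, 3 and 4 unresolved from one another in this assay. No supporting data are available to explain these results.

From the compounds shown here alone, whether an amine, a carboxylic acid or a methoxy group on this aromatic carbon would stay within the scatter remains open. Also open, going by these compounds, is how a change to the shared core, such as fluorine in place of chlorine, would read.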